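The compounds below may be only part of what the source reports. "The series", "measured", "known", "first", "only" and "open" are said of these compounds alone.

Three compounds share one core and differ only in the aromatic group hung on an oxygen on a saturated carbon. Compound 1 `COc1ccc(OC(C)(C)C2OCC(C/C=C\CCC(=O)O)C(c3cccnc3)O2)cc1` gives 41 nM in an assay for inhibition of Thromboxane-A synthase (Homo sapiens), using microsomes; a higher number here means a weaker inhibitor, a lower number a stronger inhibitor. Compound 2 `CC(C)(Oc1ccc(F)cc1)C1OCC(C/C=C\CCC(=O)O)C(c2cccnc2)O1` gives 51 nM in this assay, and compound 3 `COc1ccccc1OC(C)(C)C1OCC(C/C=C\CCC(=O)O)C(c2cccnc2)O1` gives 60 nM. Compound 3 holds the highest of the three numbers, but its steps to the others are small: a 1.5-fold higher number from compound 1 to compound 3 (0.17 log units; within the scatter) and a 1.2-fold higher number from compound 2 to compound 3 (0.07 log units; within the scatter), both within the scatter, as is a 1.2-fold higher number from compound 1 to compound 2 (0.09 log units; within the scatter).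

Compound 4 `CC(C)(Oc1ccccc1[N+](=O)[O-])C1OCC(C/C=C\CCC(=O)O)C(c2cccnc2)O1` has not been measured. It differs from compound 3 by nitro in place of methoxy on an aromatic carbon. All three measured changes of this aromatic group, a change of the substituent and two changes of its position, moved the number by less than the scatter, so the expectation for this further change of the same group is a step of no more than the scatter in either direction. Compound 4 is therefore expected to give about 70 nM in this assay, within 30 nM to 170 nM, which means an expected step of a 1.2-fold higher number from compound 3 to compound 4 (0.07 log units; within the scatter).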

Compound 4, half-maximal inhibitory concentration: < 10 nM
Compound 4 gave a limit, no number (the forecaster's own chance of this, stated with the estimate: 2%); middle value at least 7.0-fold (0.84 log units) from the limit.
By their numbers in this assay, from the lowest: compounds 1, 2 and 3 (each within the scatter of the next). At a limit, below all of these: compound 4.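

In this assay compound 4 gave a limit, not a number: the limit of < 10 nM in this assay, at which 1 of the 4 values shown sits. Among these compounds, until now this aromatic group looked insensitive to change, yet nitro in place of methoxy, ortho to a large group, gives an at least 6.0-fold lower number from compound 3 to compound 4 (0.77 log units; beyond the scatter), the first step beyond the scatter. The steps of an at least 5.1-fold lower number from compound 2 to compound 4 (0.70 log units; beyond the scatter) and an at least 4.1-fold lower number from compound 1 to compound 4 (0.61 log units; beyond the scatter) are also beyond the scatter, so the group does matter, and the position alone does not account for this, since compound 3 carries methoxy in that same place and stays within the scatter of the other two.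

On these data alone, how far the true value of compound 4 lies past its limit stays open, and with it the full size of these steps. Also open, as far as these compounds go, is whether a nitrile or an amine in that place would match nitro, and whether nitro needs that place at all.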